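The source may hold more compounds than are shown below. What is called first, only, known or untested is meant among the compounds shown, and "the series" means these compounds.

Compound 1 `CCc1cc(=O)c2ccc(OC)c(CBr)c2o1` gives > 33600 nM in a functional assay on DU-145 cells (Homo sapiens) for antiproliferative activity, read by sulforhodamine B assay, with a stated time of 72 h; a lower number here means a stronger inhibitor of growth, a higher number a weaker inhibitor of growth. Compound 2 `CCOc1ccc2c(=O)cc(CC)oc2c1CBr` gives > 32100 nM. Compound 3 `CCc1cc(=O)c2ccc(OC(C)C)c(CBr)c2o1` gives > 30700 nM. Each of these three values is a limit of the assay and not a measured number.

Compound 3 therefore stands at a limit, and the two other values shown are limits as well, so none of the three can be ranked against another. The steps a step that the two limits leave unreadable from compound 1 to compound 3 and a step that the two limits leave unreadable from compound 2 to compound 3, like the step that the two limits leave unreadable from compound 1 to compound 2, cannot be read in size or direction, since both ends of each lie at a limit. Compound 3 sits at the limit of > 30700 nM in this assay, at which 1 of the 3 values shown sits.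

Compound 4 `CCc1cc(=O)c2ccc(OCC(C)C)c(CBr)c2o1` differs from compound 3 by isobutyl in place of isopropyl on an oxygen on an aromatic ring. Within the data shown here, no measured step gives a readable size for a change of this kind at this oxygen, so nothing points to a move away from the limit. Compound 4 is therefore expected to stay at the limit, and the step that the limit leaves unreadable from compound 3 to compound 4 is the expected one. In this assay compound 4 is estimated at 35000 nM, with a range from 10000 nM to 120000 nM.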

Compound 4, concentration for 50% growth inhibition: > 29400 nM
Compound 4 ended at the assay's limit; the forecaster's own chance of this, stated with the estimate: 85%; the middle value does not contradict the limit.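

Compound 4, like compound 1, compound 2 and compound 3, stands at a limit of this assay, so no step among these four compounds can be read in size or direction. The compounds shown leave open whether any change to the shared core gives a readable value in this assay.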